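A few compounds are considered here, and "the series" means these few. Any claim that something is new, unique, unknown or untested is made for them only; others in the source may bear on it.

Measured so far in an ADME assay on L6 cells (Rattus norvegicus) for cytotoxicity, with a stated time of 72 h; a lower number here means a stronger inhibitor, a higher number a weaker inhibitor:
compound 1 `CCN(CC)CC(=O)OC1CC2(N3CCCC3)CC(c3ccccc3)C1C(c1ccccc1)C2`: 49000 nM
compound 2 `OC1CC2(N3CCCC3)CC(c3ccccc3)C1C(c1ccccc1)C2`: 26800 nM
compound 3 `CC(C)(C)C(=O)OC1CC2(N3CCCC3)CC(c3ccccc3)C1C(c1ccccc1)C2`: 7620 nM

Compound 2 holds the second highest of the three numbers in this assay. Its nearest neighbour is compound 1, with a 1.8-fold lower number from compound 1 to compound 2 (0.26 log units; within the scatter), and its furthest is compound 3, with a 3.5-fold lower number from compound 2 to compound 3 (0.55 log units; beyond the scatter); between the two esters the step is a 6.4-fold lower number from compound 1 to compound 3 (0.81 log units; beyond the scatter).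

Compound 4 `CN(C)C12CC(O)C(C(c3ccccc3)C1)C(c1ccccc1)C2` is the next compound for this assay. Relative to compound 2 the change is dimethylamino in place of pyrrolidin-1-yl on a saturated ring carbon. All three measured steps alter the group on the oxygen on a saturated carbon; none of them touches the amine on the saturated ring carbon, and the hydroxy group of compound 2 is retained in compound 4. For the measured compounds named here, no measured step therefore bears directly on this change, and the expected step in this assay is none beyond the scatter. Compound 4 is expected to give 26800 nM, with a range from 9000 nM to 80000 nM. The expected step is no change at the digits printed from compound 2 to compound 4 (within the scatter).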

Compound 4, half-maximal inhibitory concentration: 133000 nM
Compound 4: middle estimate off by 5.0-fold (0.70 log units), on the low side; measured number above the stated range.
By their numbers in this assay, from the lowest: compound 3; then compounds 2 and 1 (each within the scatter of the next); then compound 4.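

The amine on the saturated ring carbon is a position that affects the read-out in this assay: with the hydroxy group held constant, dimethylamino in place of pyrrolidin-1-yl gives a 5.0-fold higher number from compound 2 to compound 4 (0.70 log units; beyond the scatter). For the compounds shown here, until now, all measured steps had altered only the group on the oxygen, so this is the first sign that the series responds to a change at the amine as well. In this single pair, the open dimethylamino group, with no ring and fewer heavy atoms, goes with the higher number, and no supporting data bear on the reason for the step.

Open, going by these compounds, is whether ring or heavy-atom count governs the step, which piperidin-1-yl or diethylamino on the same carbon could help separate. Also open, on these data alone, is whether the same exchange carries over to the (tert-butyl)carbonyl ester, compound 3.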